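Swapping Methyl for Chloro on a Glutamate Receptor Modulator

This account rests on a few compounds, and the source may have more. Where it says the series, first, only, none or still open, it means among the compounds named here.

For the measured compounds named here, compound 1, with structure `Cc1cccc(-c2noc(C3CN(S(=O)(=O)c4ccc(Cl)cc4)C3)n2)c1`, is the only compound here with a numerical result: in an assay on HEK293 cells for negative allosteric modulation of metabotropic glutamate receptor 5 (Homo sapiens), read by FLIPR (on this read-out higher numbers stand for weaker inhibition and lower numbers for stronger inhibition), compound 1 gives 1100 nM. Compound 2, with structure `O=C(C1CCC(F)(F)CC1)N1CC(c2nc(-c3cccc(Cl)c3)no2)C1`, sits at a limit of the assay rather than a number; in this assay compound 2 gives > 10000 nM. Compound 3, with structure `O=C(C1CCCCC1)N1CC(c2nc(-c3cccc(F)c3)no2)C1`, likewise sits at a limit; in this assay compound 3 gives > 10000 nM. Two of the three results thus rest at the limit of > 10000 nM in this assay, at which 2 of the 3 values shown sit. Compounds 2 and 3 differ from compound 1 in more than one place, so no single step can be read between them.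

Compound 4, with structure `O=S(=O)(c1ccc(Cl)cc1)N1CC(c2nc(-c3cccc(Cl)c3)no2)C1`, has not yet been measured. It arises from compound 1 by one change: chloro in place of methyl on an aromatic carbon. Compound 2 also carries the 3-chlorophenyl group but differs from compound 1 elsewhere too, so the exchange is not isolated by any measured pair. A step of this size is expected to stay within the usual scatter, with no clear direction. The expected step in this assay is a 1.1-fold higher number from compound 1 to compound 4 (0.04 log units; within the scatter). Compound 4 is therefore estimated to give about 1200 nM in this assay, between 400 nM and 3500 nM.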

Compound 4, half-maximal inhibitory concentration: 170 nM
Beside the measured number, compound 4's estimate is 7.1-fold (0.85 log units) above it; the whole stated range lies above it.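

Changing 3-methylphenyl to 3-chlorophenyl gives a 6.5-fold lower number from compound 1 to compound 4 (0.81 log units; beyond the scatter) in this assay, which means stronger inhibition by a margin beyond the scatter. For the compounds shown here, this is the first step in the set that can be read at a single place, and it shows that this position on the aromatic ring responds clearly to the exchange of one heavy atom for another, even though neither group adds a ring, a hydrogen-bond donor or acceptor, or a charge. Nothing measured here accounts for why chloro gives the lower number.

From the compounds shown here alone, what a trifluoromethyl, a nitrile or a methoxy group would do in this same place on the core of compound 4 remains open. One step also cannot say whether this exchange would give a similar result on a different core.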